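The source may report more compounds than this note shows. Statements on the series, on what has been measured and on what is new or still open speak of the compounds shown alone.

Compound 1 `CCCCN(c1nc2c(NC(C)=O)cccc2o1)[C@H](C)c1ccc(-c2ccccc2-c2nnn[nH]2)cc1` gives 26.6 nM in an ADME assay on the whole organism (Macaca fascicularis) for pharmacokinetics, read by LC-MS, using cassette dosing, at a dose of 1 mg/kg by the oral route (on this read-out lower numbers stand for lower exposure and higher numbers for higher exposure at the dose given), the lower of the two numbers recorded. Compound 2 `CCCCN(c1nc2c(C(=O)O)cccc2o1)[C@H](C)c1ccc(-c2cc(Cl)ccc2-c2nc(=O)o[nH]2)cc1` gives 677 nM in this assay, a gap that lies beyond the scatter. Compound 3 `CCCCN(c1nc2c(C(=O)N(C)C)cccc2o1)[C@H](C)c1ccc(-c2ccccc2-c2nnn[nH]2)cc1` is not yet measured; it differs from compound 1 in one place: dimethylcarbamoyl in place of acetamido on an aromatic carbon. Among the measured compounds shown here, no pair differing in a single place has both values recorded, so nothing measured anchors the size of this step. A small rise is expected, a 1.9-fold higher number from compound 1 to compound 3 (0.27 log units; within the scatter), since compound 1 sits at the low end with 26.6 nM. Compound 3 is estimated at 50 nM, likely between 10 nM and 250 nM.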

Compound 3, maximal plasma concentration: 54 nM
Compound 3: middle estimate off by 1.1-fold (0.03 log units), on the low side; measured number inside the range.
By their numbers in this assay, from the lowest: compound 1; then compound 3; then compound 2.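

In this assay, among the compounds shown here, dimethylcarbamoyl in place of acetamido on this aromatic carbon gives a 2.0-fold higher number from compound 1 to compound 3 (0.31 log units; beyond the scatter) as the first step that can be read at this position. The change swaps a group with a hydrogen-bond donor for one without, and the step stays modest. Nothing measured here accounts for the step. As far as these compounds go, it remains open whether methylcarbamoyl, which would keep a donor in the amide, or an amine at this same place would move the number further on the core of compound 1.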